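The source may hold more compounds than are shown below. What is called first, only, known or untested is meant among the compounds shown, and "the series" means these compounds.

Compound 1 `CCn1ncc(-c2nc3c(N[C@H]4CCN(C(=O)C5CC5)C4)ncnc3n2C)c1C` and compound 2 `CCn1ncc(-c2nc3c(N4CCC(n5c(=O)[nH]c6ncccc65)CC4)ncnc3n2C)c1C` share one core and have both been measured in a physicochemical assay for lipophilicity; on this read-out lower numbers stand for lower lipophilicity and higher numbers for higher lipophilicity. In this assay compound 1 gives 1, the lower of the two numbers; compound 2 gives 1.4, a gap beyond the usual scatter. Compound 3 `CCC(=O)N1CC[C@H](Nc2ncnc3c2nc(-c2cnn(CC)c2C)n3C)C1` has not yet been measured. Relative to compound 1 the change is ethyl in place of cyclopropyl on a carbonyl carbon, which removes one carbon and a three-membered ring without altering donor or acceptor counts. The step from compound 1 to compound 3 in this assay is expected to be small and slightly downward, at most near the edge of the scatter, a number 0.15 log units lower from compound 1 to compound 3 (within the scatter). Compound 3 is therefore estimated at 0.85, with a likely range from 0.55 to 1.15.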

Compound 3, distribution coefficient: 0.8
Estimate against measurement, compound 3: 0.05 log units above; the range from low to high includes it.
By their numbers in this assay, from the lowest: compounds 3 and 1 (each within the scatter of the next); then compound 2.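

Ethyl in place of cyclopropyl on a carbonyl carbon gives a number 0.20 log units lower from compound 1 to compound 3 (within the scatter) in this assay, and this is the first step in the series that can be read at a single place. On this one pair, losing the three-membered ring and one carbon leaves the read-out within the scatter. No measurement at hand explains this result. As far as these compounds go, how this position responds to a longer chain, an amine or a carboxylic acid on the same carbonyl carbon stays open.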